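Swapping Methyl for Bromo on a Growth Inhibitor

The compounds below may be only part of what the source reports. "The series", "measured", "known", "first", "only" and "open" are said of these compounds alone.

Of the compounds shown here, two have numbers so far in a functional assay on 786-0 cells (Homo sapiens) for inhibition, read by sulforhodamine B assay, with a stated time of 48 h (a lower number here means a stronger inhibitor of growth, a higher number a weaker inhibitor of growth), where compound 1 `Cc1ccc(NC(=S)N/N=C/c2cccs2)cc1` gives 19500 nM and compound 2 `C=CCNC(=S)N/N=C/c1cccs1` gives 21200 nM as its result. These two numbers lie within the usual scatter of repeated measurements, so compound 1 stands level with compound 2 and neither can be ranked.

The next compound, compound 3 `S=C(N/N=C/c1cccs1)Nc1ccc(Br)cc1` keeps the core of compound 1 and changes one group: bromo in place of methyl on an aromatic carbon (bromo in place of methyl on an aromatic carbon, para to a large group). Within the data shown here, no measured pair here shows what such a swap does, so any forecast remains cautious. The step expected in this assay is a 1.3-fold lower number from compound 1 to compound 3 (0.11 log units; within the scatter) and this estimated step stays within the scatter, with no clear direction. Compound 3 is estimated to give 15000 nM with 6000 nM to 35000 nM as the expected range.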

Compound 3, concentration for 50% growth inhibition: 4500 nM
Beside the measured number, compound 3's estimate is 3.3-fold (0.52 log units) above it; measured number below the stated range.
By their numbers in this assay, from the lowest: compound 3; then compounds 1 and 2 (each within the scatter of the next).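

This position, on a six-membered aromatic ring of carbon only and para to a large group, responds to the change in this assay: bromo in place of methyl gives a 4.3-fold lower number from compound 1 to compound 3 (0.64 log units; beyond the scatter), a modest step but one beyond the scatter. The earlier compounds shown here gave no such reading, as their two numbers could not be ranked and no swap at this position had a number. One heavy atom replaces one heavy atom, with no hydrogen-bond donor, acceptor or net charge entering or leaving, so these counts do not separate the two groups, and no measurement at hand accounts for the step.

Going by these compounds, it remains open whether chloro, methoxy or trifluoromethyl at this same place would track bromo or methyl. A single pair also cannot say whether bromo would bring a similar step on a different core.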